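Ring-constrained amine in place of an open chain

The source may hold more compounds than are shown below. What is called first, only, known or untested is meant among the compounds shown, and "the series" means these compounds.

Among the measured compounds shown here, the three compounds measured so far share a bicyclic fragment carrying a ring nitrogen-hydrogen, attached to differing cores. Compound 1, `Nc1ncnc2c1c(-c1ccc3cc[nH]c3c1)cn2-c1ccc(OCCNCCO)cc1`, gives 30000 nM in an assay on isolated protein for inhibition of thyroid peroxidase (Homo sapiens); on this read-out lower numbers stand for stronger inhibition and higher numbers for weaker inhibition. Compound 2, `CN(C)Cc1ccc(-n2cc(-c3ccc4cc[nH]c4c3)c3c(Cl)ccnc32)cc1`, gives 5300 nM in this assay. Compound 3, `NCCCCn1cc(-c2ccc3cc[nH]c3c2)c(C(F)(F)F)n1`, reaches only a limit of the measurement, > 30000 nM in this assay; this is the boundary described by the limit of > 30000 nM in this assay, at which 1 of the 3 values shown sits, so for compound 3 a range rather than a number is known, and its true value lies somewhere at or beyond that boundary. Of the three, only compound 2 sits clearly inside the measurable window.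

Compound 4, `NC[C@H]1C[C@H](n2cc(-c3ccc4cc[nH]c4c3)c(C(F)(F)F)n2)C1`, differs from compound 3 by a group of 6 heavy atoms (5 carbon, 1 nitrogen; one four-membered non-aromatic ring of carbon only) in place of a group of 5 heavy atoms (4 carbon, 1 nitrogen; no ring), on an aromatic nitrogen. The amine is kept, but the open chain is replaced by a group built on a four-membered non-aromatic ring of carbon only, with two defined stereocentres. For the measured compounds named here, no pair of measured compounds differs only in this way, so the size of the step cannot be read off from the data and rests on the starting point alone. Since compound 3 gives > 30000 nM, compound 4 is expected to remain in the weak range, with a step of a number no higher from compound 3 to compound 4 (the limit leaves the size open) that is not expected to exceed the usual scatter. The estimate for compound 4 is 30000 nM, within a range from 8000 nM to 100000 nM.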

Compound 4, half-maximal inhibitory concentration: > 30000 nM
Compound 4 ended at the assay's limit (the forecaster's own chance of this, stated with the estimate: 60%); the middle value lies on the limit itself.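

Compound 3 and compound 4 both stand at a limit in this assay, so no step between them can be read: the limit of > 30000 nM in this assay, at which 2 of the 4 values shown sit.

The compounds shown leave open whether the 4-aminobutyl chain and the group built on the four-membered ring differ at all, and how either would behave on the core of compound 2.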